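This account rests on a few compounds, and the source may have more. Where it says the series, first, only, none or still open, it means among the compounds named here.

Of the compounds shown here, two in this set have been measured so far. Going by the values given here, compound 1 `COc1ccc2nc(NC(=O)c3cn(-c4ccccc4)nc3-c3ccc(Cl)cc3)sc2c1` and compound 2 `COc1ccc(-c2nn(-c3ccccc3)cc2C(=O)Nc2nc3ccc(F)cc3s2)cc1` share a core and differ at two places at once, so no single step between them can be read. In a functional assay on HT-29 cells (Homo sapiens) for cytotoxicity, read by MTT assay, with a stated time of 72 h (a higher number here means a weaker inhibitor, a lower number a stronger inhibitor), compound 1 gives 18600 nM. In this assay compound 2 gives 5560 nM, the lower of the two numbers, and the gap to compound 1 lies beyond the usual scatter.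

Compound 3 `COc1ccc(-c2nn(-c3ccccc3)cc2C(=O)Nc2nc3ccc(OC)cc3s2)cc1` is the next compound and has not yet been measured. It differs from compound 2 in one place: methoxy in place of fluoro on an aromatic carbon. Put one bond further out, the change reads 6-fluoro-1,3-benzothiazol-2-yl to 6-methoxy-1,3-benzothiazol-2-yl.

Among the compounds with values here, no measured pair shows this change on its own, so the direction of the step cannot be read from the data. Compound 1, which carries the methoxy on the same fused ring, gives 18600 nM in this assay, but it also differs elsewhere, so that number cannot be tied to this change. Compound 3 is therefore expected to land near compound 2, with the step of a 1.4-fold higher number from compound 2 to compound 3 (0.16 log units; within the scatter) expected to be small and within or just beyond the scatter. For compound 3 the estimate in this assay is 8000 nM, in a range from 3000 nM to 25000 nM.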

Compound 3, half-maximal inhibitory concentration: > 50000 nM
Compound 3 ended at the assay's limit; the forecaster's own chance of this, stated with the estimate: 5%; at least 6.2-fold (0.79 log units) between middle value and limit.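

Read on its own for the first time, methoxy in place of fluoro on the fused ring, the change from 6-fluoro-1,3-benzothiazol-2-yl to 6-methoxy-1,3-benzothiazol-2-yl, gives an at least 8.9-fold higher number from compound 2 to compound 3 (0.95 log units; beyond the scatter) in this assay, so this position does not tolerate the swap without a clear loss of activity in these cells. The second readable step keeps that methoxy on the fused ring and replaces the chloro of the other aromatic substituent with a methoxy, and gives an at least 2.6-fold higher number from compound 1 to compound 3 (0.42 log units; beyond the scatter), which shows that the number also responds to a change elsewhere in the molecule. Compound 3 stands at a limit of the assay, not at a number, so both steps give only the smallest size the change can have: the limit of > 50000 nM in this assay, at which 1 of the 3 values shown sits.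

As far as these compounds go, no step can be read between compound 1 and compound 2, which differ at two places, and how far compound 3 lies past its limit stays unknown. From the compounds shown here alone, whether an amine, a hydroxyl or a longer chain such as ethoxy in place of the fluoro would follow fluoro or methoxy remains open, as does how fluoro on the fused ring behaves alongside chloro on the other aromatic ring.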